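A few compounds are considered here, and "the series" means these few. Any claim that something is new, unique, unknown or untested is made for them only; others in the source may bear on it.

Three compounds of the series are measured: compound 1 `CN(C)C12CCN(CCCN3CCCCC3)C(C(c3ccccc3)C1)C(c1ccccc1)C2`, compound 2 `CN1CCN(CCC(=O)N2CCC3(N4CCCC4)CC(c4ccccc4)C2C(c2ccccc2)C3)CC1` and compound 3 `c1ccc(C2CC3(N4CCCC4)CCN(CCN4CCCC4)C2C(c2ccccc2)C3)cc1`. In an ADME assay on L6 cells (Rattus norvegicus) for cytotoxicity (a higher number here means a weaker inhibitor, a lower number a stronger inhibitor), compound 1 gives 58400 nM, compound 2 gives 75400 nM and compound 3 gives 58200 nM. Compound 3 carries the lowest of the three numbers, but all three lie within the scatter of one another, so the series is flat so far. Within the data shown here, the single recorded step is a 1.3-fold lower number from compound 2 to compound 3 (0.11 log units; within the scatter), a change on an amine nitrogen in a ring rather than on the saturated chain carbon altered below. Compound 4 `c1ccc(C2CC3(N4CCCC4)CCN(CCCN4CCCCC4)C2C(c2ccccc2)C3)cc1` is not yet measured; it differs from compound 3 as follows: (piperidin-1-yl)methyl in place of pyrrolidin-1-yl on a saturated chain carbon, two bonds along the chain from an amine nitrogen in a ring. Among the measured compounds shown here, compound 1 already carries the 3-(piperidin-1-yl)propyl chain, and its number in this assay sits beside that of compound 3, though the two differ elsewhere as well and no step between them is recorded. Nothing measured points to a move beyond the scatter, so in this assay compound 4 is expected to give 58000 nM, range 30000 nM to 115000 nM. The expected step is a 1.0-fold lower number from compound 3 to compound 4 (0.00 log units; within the scatter).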

Compound 4, half-maximal inhibitory concentration: 28700 nM
Estimate against measurement, compound 4: 2.0-fold (0.31 log units) above; measured number outside the range, below it.
By their numbers in this assay, from the lowest: compound 4; then compounds 3, 1 and 2 (each within the scatter of the next).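

Among these compounds, at the saturated chain carbon, two bonds along the chain from an amine nitrogen in a ring, (piperidin-1-yl)methyl in place of pyrrolidin-1-yl gives the first step beyond the scatter in this assay: a 2.0-fold lower number from compound 3 to compound 4 (0.31 log units; beyond the scatter). Compound 4 also separates from the two other compounds, with a 2.6-fold lower number from compound 2 to compound 4 (0.42 log units; beyond the scatter) for 3-(piperidin-1-yl)propyl in place of (2-(4-methylpiperazin-1-yl)ethyl)carbonyl on an amine nitrogen in a ring, and a 2.0-fold lower number from compound 1 to compound 4 (0.31 log units; beyond the scatter) for pyrrolidin-1-yl in place of dimethylamino on a saturated ring carbon. All three steps are modest, and nothing available explains them.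

Chain length and ring size change together from compound 3 to compound 4, so their shares of the step remain open. A 3-(pyrrolidin-1-yl)propyl or 2-(piperidin-1-yl)ethyl chain on the ring nitrogen would separate the two.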